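Working notes on compound 3 in the series

The compounds below may be only part of what the source reports. "The series", "measured", "known", "first", "only" and "open" are said of these compounds alone.

Measured so far:
compound 1 `O=C(CN1CCN(c2ccccc2)CC1)N(c1ccccc1)c1ccccc1`; in a functional assay on the whole organism (strain Swiss albino) for inhibition, with Mus musculus as the target, with stated times of 10 min, 5 min and 20 min (a lower number here means that less compound is needed, a higher number that more compound is needed for the effect), compound 1 gives 20.5 mg/kg
compound 2 `COc1cccc(N2CCN(CC(=O)N(c3ccccc3)c3ccccc3)CC2)c1`; in this assay compound 2 gives 10 mg/kg

Among the compounds with values here, compound 2 holds the lowest of the two numbers; its only neighbour is compound 1, and the step of a 2.1-fold lower number from compound 1 to compound 2 (0.31 log units; beyond the scatter) is a modest gain from methoxy in place of hydrogen on an aromatic carbon. Compound 3 `O=C(CN1CCN(c2ccc(F)cc2)CC1)N(c1ccccc1)c1ccccc1` differs from compound 2 by 4-fluorophenyl in place of 3-methoxyphenyl on an amine nitrogen in a ring. Within the data shown here, no measured step covers this swap directly. Among the measured compounds shown here, the one known step, a 2.1-fold lower number from compound 1 to compound 2 (0.31 log units; beyond the scatter), indicates that giving up the 3-methoxyphenyl costs a modest gain, while the 4-fluorophenyl has no precedent here. A small rise in the number is therefore expected in this assay, a 1.6-fold higher number from compound 2 to compound 3 (0.20 log units; within the scatter). Compound 3 is estimated at 16 mg/kg, with a range from 8 mg/kg to 35 mg/kg.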

Compound 3, dose for half-maximal effect: 13.4 mg/kg
For compound 3 the middle estimate is 1.2-fold (0.08 log units) above the measured one; the range from low to high includes it.
By their numbers in this assay, from the lowest: compounds 2, 3 and 1 (each within the scatter of the next, the first and the last beyond it).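

In this assay, 4-fluorophenyl on the amine nitrogen in a ring gives a 1.3-fold higher number from compound 2 to compound 3 (0.13 log units; within the scatter) and so cannot be told apart from 3-methoxyphenyl at this position. Fluoro in place of hydrogen on an aromatic carbon gives a 1.5-fold lower number from compound 1 to compound 3 (0.18 log units; within the scatter) and so cannot be told apart from hydrogen, which places compound 3 within reach of both compound 1 and compound 2, although those two lie beyond the scatter of each other. No evidence on the cause of these steps is at hand.

On these data alone, what a nitrile or a primary amine on that phenyl ring would give remains open. So does the effect of any change elsewhere on the shared core.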